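Amide substituent variation in a dimethoxy-fused bicyclic acetamide series

The source may hold more compounds than are shown below. What is called first, only, known or untested is meant among the compounds shown, and "the series" means these compounds.

Measured so far:
compound 1 `CNC(=O)CC1CCc2cc(OC)c(OC)cc21` gives 15.6%
compound 2 `CCCCCCNC(=O)CC1CCc2cc(OC)c(OC)cc21` gives 47.6%
compound 3 `COc1cc2c(cc1OC)C(CC(=O)NC1CCCC1)CC2` gives 40.6%

All three share one core and differ only at the amide nitrogen; the read-out is a functional assay on the whole organism (strain Wistar) for inhibition, with Rattus norvegicus as the target, read by paw edema, with stated times of 60 min and 1 h, at a dose of 100 mg/kg by the oral route; on this read-out lower numbers stand for less inhibition and higher numbers for more inhibition at the one dose given (going by the name of the read-out). Compound 3 stands second highest of the three, set apart from compound 1 by a number 25 percentage points higher from compound 1 to compound 3 (beyond the scatter), while against compound 2 the gap is a number 7 percentage points lower from compound 2 to compound 3 (within the scatter). The larger amide substituents have given the higher numbers, as a number 32 percentage points higher from compound 1 to compound 2 (beyond the scatter) also shows.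

Compound 4 `COc1cc2c(cc1OC)C(CC(=O)N1CCOCC1)CC2` carries morpholin-4-yl in place of cyclopentylamino on a carbonyl carbon. Among the measured compounds shown here, no measured step removes the amide hydrogen; the size of the group is kept, so the steps suggest no large change, with some risk downward. Compound 4 is expected to give 32%, within 15% to 48%, a step estimated as a number 8.6 percentage points lower from compound 3 to compound 4 (within the scatter).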

Compound 4, a percentage reported as inhibition, in the whole organism at one dose (the size of the read-out at that dose, not a potency): 15.6%
The estimate for compound 4 lay 16.4 percentage points above the measured number; the measured number falls inside the stated range.
By their numbers in this assay, from the lowest: compounds 1 and 4 (each within the scatter of the next); then compounds 3 and 2 (each within the scatter of the next).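

In this assay, morpholin-4-yl on the carbonyl carbon does not hold the level of the larger groups, with a number 25 percentage points lower from compound 3 to compound 4 (beyond the scatter) and a number 32 percentage points lower from compound 2 to compound 4 (beyond the scatter). Group size alone therefore does not set the read-out: morpholin-4-yl matches cyclopentylamino in heavy atoms, yet the comparison with the small methylamino group gives no change at the digits printed from compound 1 to compound 4 (within the scatter). This change also removes the amide hydrogen and brings in a ring oxygen, and nothing at hand shows which of these matters.

Open, from the compounds shown here alone, is how piperidin-1-yl, which lacks the amide hydrogen but has no ring oxygen, would read. Going by these compounds, a longer chain than hexylamino is also open.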